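A few compounds are considered here, and "the series" means these few. Any claim that something is new, unique, unknown or untested is made for them only; others in the source may bear on it.

Values so far in an ADME assay on RAW264.7 cells (Mus musculus) for cytotoxicity, read by MTT assay, with a stated time of 24 h; on this read-out higher numbers stand for weaker inhibition and lower numbers for stronger inhibition

compound 1 `CC(=O)S[C@@]12CC[C@H](O)[C@@H]1C(=O)NC2=O` gives 559000 nM 
compound 2 `CC(=O)S[C@]12CC[C@H](O)[C@H]1C(=O)NC2=O` gives 857000 nM 
compound 3 `CC(=O)S[C@]12CCC[C@H]1C(=O)NC2=O` gives 674000 nM 

Compound 2 is not separated from its two neighbours, since both measured steps that reach it stay inside the scatter. Between the two stereoisomers the step is a 1.5-fold higher number from compound 1 to compound 2 (0.19 log units; within the scatter) and the structures show the fact that compounds 1 and 2 differ only in the configuration as drawn as the whole of the difference. Hydrogen in place of hydroxy on a saturated ring carbon gives a 1.3-fold lower number from compound 2 to compound 3 (0.10 log units; within the scatter) and again separates nothing.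

Compound 4 `O=C(S[C@]12CC[C@H](O)[C@H]1C(=O)NC2=O)c1ccccc1` keeps the core of compound 2 and changes one group, with phenyl in place of methyl on a carbonyl carbon, counted as phenyl in place of methyl on a carbonyl carbon in full. Neither measured step touches that carbonyl carbon, so they bear on this change only indirectly. They show how little the numbers have moved so far in this assay and give no direction for this change. Compound 2 moved no further than a 1.5-fold higher number from compound 1 to compound 2 (0.19 log units; within the scatter) on any change tested, and the new change is larger by count than the hydroxy change. The expected step is a 1.7-fold lower number from compound 2 to compound 4 (0.23 log units; within the scatter) as an estimate, so nothing beyond the scatter is expected, although a lower number seems somewhat more likely than a higher one. The estimate for compound 4 is 500000 nM as the expected value, running from 150000 nM to 1000000 nM at its estimated upper end.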

Compound 4, half-maximal inhibitory concentration: 17100000 nM
For compound 4 the middle estimate is 34-fold (1.53 log units) below the measured one; measured number above the stated range.
By their numbers in this assay, from the lowest: compounds 1, 3 and 2 (each within the scatter of the next); then compound 4.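

In this assay, going by these compounds alone, the carbonyl carbon whose other neighbour is sulfur is the first place where a change moves the number beyond the scatter, and the move is large: a 20-fold higher number from compound 2 to compound 4 (1.30 log units; beyond the scatter). The change of configuration and the loss of hydroxy left the numbers inside the scatter, so among the compounds shown this carbonyl carbon is the only place that separates anything, and phenyl in place of methyl goes towards weaker inhibition on this read-out. No measurement given here accounts for the size of this step, as the single recorded fact concerns configuration and does not touch this carbonyl carbon.

Still open, from the compounds shown here alone, is whether the step follows the aromatic ring itself or simply the larger count of heavy atoms; an ethyl, cyclohexyl or benzyl group on the same carbonyl carbon would bear on that. Also open, going by these compounds, is whether phenyl gives a similar step on the configuration of compound 1 or on the core of compound 3, which lacks the hydroxy.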